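Swapping a fluorophenyl for a benzothiophene on the shared core

The source may report more compounds than this note shows. Statements on the series, on what has been measured and on what is new or still open speak of the compounds shown alone.

Three compounds share a common core and differ only in the aromatic group attached to it. Compound 1 `Cc1cc(-c2cccc(F)c2)nnc1N1CCN(c2ncccn2)CC1`, compound 2 `Cc1cc(-c2ccc(F)cc2)nnc1N1CCN(c2ncccn2)CC1` and compound 3 `Cc1cc(-c2ccsc2)nnc1N1CCN(c2ncccn2)CC1` were all tested in a functional assay on BV-2 cells (Mus musculus) for inhibition, read by ELISA, with a stated time of 16 h; on this read-out lower numbers stand for stronger inhibition and higher numbers for weaker inhibition. There compound 1 gives 33500 nM, compound 2 gives 76300 nM and compound 3 gives 2400 nM. Compound 1 thus stands second highest of the three numbers, with a 2.3-fold higher number from compound 1 to compound 2 (0.36 log units; beyond the scatter), and a 14-fold lower number from compound 1 to compound 3 (1.14 log units; beyond the scatter).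

Compound 4 `Cc1cc(-c2cc3ccccc3s2)nnc1N1CCN(c2ncccn2)CC1` has not yet been measured. It differs from compound 1 in one place: 1-benzothiophen-2-yl in place of 3-fluorophenyl on an aromatic carbon. Going by the values given here, the only measured step that bears on this change is the one in which a five-membered aromatic ring with a sulfur atom also replaced the fluorophenyl, namely a 14-fold lower number from compound 1 to compound 3 (1.14 log units; beyond the scatter), and in the same direction a 32-fold lower number from compound 2 to compound 3 (1.50 log units; beyond the scatter). Both were large and downward. A downward step is therefore expected here too, and for compound 4 the estimate is 6000 nM, with a range from 1500 nM to 25000 nM, which corresponds to a 5.6-fold lower number from compound 1 to compound 4 (0.75 log units; beyond the scatter) as the expected step.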

Compound 4, half-maximal inhibitory concentration: 24900 nM
For compound 4 the middle estimate is 4.2-fold (0.62 log units) below the measured one; the measured number falls inside the stated range.
By their numbers in this assay, from the lowest: compound 3; then compounds 4 and 1 (each within the scatter of the next); then compound 2.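

A sulfur-containing ring at this position does not by itself bring the gain seen with compound 3: with the 1-benzothiophen-2-yl group there is a 1.3-fold lower number from compound 1 to compound 4 (0.13 log units; within the scatter), so the two cannot be told apart in this assay. The gain is instead specific to the smaller thiophen-3-yl group, as the fused group gives a 10-fold higher number from compound 3 to compound 4 (1.02 log units; beyond the scatter), though it still retains a modest edge over the 4-fluorophenyl group, with a 3.1-fold lower number from compound 2 to compound 4 (0.49 log units; beyond the scatter). No available evidence explains why these groups differ.

The step from compound 3 to compound 4 adds a fused benzene ring and also moves the point of attachment from the 3-position to the 2-position of the thiophene, so the two changes cannot be separated. A thiophen-2-yl group would separate them, and a furan-3-yl group would show whether the sulfur atom matters at all.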